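This account rests on a few compounds, and the source may have more. Where it says the series, first, only, none or still open, it means among the compounds named here.

Measured compounds:
Compound 1, `COc1ccc(-c2cnc(NC(=O)c3ccno3)n2C)cc1`, gives > 100000 nM.
Compound 2, `COc1ccc(-c2cnc(NC(=O)c3ccccc3C#N)n2C)cc1`, gives > 100000 nM.

In a toxicity assay on THP-1 cells (Homo sapiens) for inhibition (on this read-out lower numbers stand for higher toxicity in this test and higher numbers for lower toxicity in this test), compound 2 stands at a limit of the assay, > 100000 nM, and not at a number. Compound 1 likewise returns only a limit, > 100000 nM. Both results sit at the limit of > 100000 nM in this assay, at which 2 of the 2 values shown sit. Among the compounds with values here, the single measured step, a step that the two limits leave unreadable from compound 1 to compound 2, therefore cannot be read, and no size can be taken from it.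

Compound 3, `COc1ccc(-c2cnc(NC(=O)c3ccc(C#N)cc3)n2C)cc1`, differs from compound 2 by 4-cyanophenyl in place of 2-cyanophenyl on a carbonyl carbon. Within the data shown here, no measured step bears on that change, and the one step that exists is itself unreadable. Nothing here points to a shift beyond the usual scatter in either direction. Compound 3 is accordingly expected to sit again at the limit, with an estimated value of 100000 nM, ranging from 50000 nM to 200000 nM. The step this estimate implies is a number no higher from compound 2 to compound 3 (the limit leaves the size open), expected to be negligible.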

Compound 3, half-maximal cytotoxic concentration: > 100000 nM
Compound 3 ended at the assay's limit; the forecaster's own chance of this, stated with the estimate: 80%; the middle value sits exactly at the limit.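

In this assay compound 3 gives > 100000 nM, a limit of the assay and not a number. Within the data shown here, no step among compound 1, compound 2 and compound 3 can be read, and all three share one limit: the limit of > 100000 nM in this assay, at which 3 of the 3 values shown sit. The compounds shown leave open how far any of these groups on the carbonyl carbon changes toxicity in this test.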